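Dropping the fluoro from the aromatic ring of compound 3

The source may hold more compounds than are shown below. What is called first, only, known or untested is meant among the compounds shown, and "the series" means these compounds.

The compounds measured so far, with their results in a functional assay on the whole organism (strain Swiss) with Mus musculus as the target, in the maximal electroshock model, with a stated time of 2 h, at a dose of 300 mg/kg by the intraperitoneal route; on this read-out higher numbers stand for a stronger effect at the one dose given and lower numbers for a weaker effect:
compound 1 `CCC(C(=O)N1CCN(c2ccccc2)CC1)N1C(=O)CCC1=O` gives 25%;
compound 2 `CC(C(=O)N1CCN(c2ccc(F)cc2)CC1)N1C(=O)CCC1=O` gives 50%;
compound 3 `CC(C(=O)N1CCN(c2ccccc2F)CC1)N1C(=O)CCC1=O` gives 25%.

Compound 3 stands level with compound 1 at the digits shown, and the two together are the lowest of the three numbers. Among the compounds with values here, compound 2 stands higher, and the one measured step that ends at compound 3 is a number 25 percentage points lower from compound 2 to compound 3 (beyond the scatter).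

Compound 4 `CC(C(=O)N1CCN(c2ccccc2)CC1)N1C(=O)CCC1=O` is the next one to be measured. It differs from compound 3 in one place: hydrogen in place of fluoro on an aromatic carbon.

Within the data shown here, no measured step removes a fluoro from the aromatic ring, so nothing bears on this change directly. Among the measured compounds shown here, the only measured step that touches that ring, the one from compound 2 to compound 3, moved the fluoro rather than removing it. Compound 1, which carries a ring without fluoro but a longer chain next to the amide, gives 25%, the same figure as compound 3. On that slim basis the expected step is a number 5 percentage points higher from compound 3 to compound 4 (within the scatter), that is, no change beyond the scatter. The estimate for compound 4 in this assay is therefore 30%, with a range from 10% to 55%.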

Compound 4, a percentage reported as activity, at one dose (the size of the read-out at that dose, not a potency): 0%
The estimate for compound 4 lay 30 percentage points above the measured number, and the stated range ends above it.
By their numbers in this assay, from the lowest: compound 4; then compounds 1 and 3 (each within the scatter of the next); then compound 2.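

In this assay, hydrogen in place of fluoro on the aromatic ring gives a number 25 percentage points lower from compound 3 to compound 4 (beyond the scatter), and the same exchange starting from the 4-fluorophenyl compound gives a number 50 percentage points lower from compound 2 to compound 4 (beyond the scatter), which is the large step of the two; among these compounds, then, a fluoro at either ring place reads higher than the plain phenyl ring. The chain matters as well, for with the phenyl ring unchanged, hydrogen in place of methyl on the saturated chain carbon gives a number 25 percentage points lower from compound 1 to compound 4 (beyond the scatter), so compound 4 falls below both its fluoro relatives and its longer-chain relative. Nothing at hand gives a reason for these drops.

From the compounds shown here alone, whether a chlorine or a methoxy group on the ring would lift the read-out as fluoro does remains open, and so does whether a fluoro and the longer chain together would reach beyond either alone. Each figure also belongs to a single dose, so these compounds leave open how the effect would change at lower or higher doses.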